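Propyl in Place of Phenyl on a Second Core

This account rests on a few compounds, and the source may have more. Where it says the series, first, only, none or still open, it means among the compounds named here.

In an assay on membranes from lung (Cavia porcellus) for binding affinity to cysteinyl leukotriene receptor (Homo sapiens) (on this read-out higher numbers stand for weaker inhibition and lower numbers for stronger inhibition), compound 1 `O=C(O)CCC(Cc1ccc(OCc2ccc3ccccc3n2)cc1)c1ccccc1` gives 31 nM. Compound 2 `CCCC(CCC(=O)O)Cc1ccc(OCc2ccc3ccccc3n2)cc1` differs from it by propyl in place of phenyl on a saturated chain carbon bound to two saturated chain carbons and in this assay compound 2 gives 21 nM; the step of a 1.5-fold lower number from compound 1 to compound 2 (0.17 log units; within the scatter) lies within the scatter of repeated measurements. Compound 3 `c1ccc(C(CCc2nnn[nH]2)Cc2cccc(OCc3ccc4ccccc4n3)c2)cc1` is built on a different core; the difference between the two cores is not broken down here. In this assay compound 3 gives 14 nM, which is within the scatter of compound 2 and beyond the scatter of compound 1.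

Compound 4 `CCCC(CCc1nnn[nH]1)Cc1cccc(OCc2ccc3ccccc3n2)c1` has not yet been measured. It carries on the core of compound 3 the same change that compound 2 carries on the core of compound 1: propyl in place of phenyl on a saturated chain carbon bound to two saturated chain carbons, the place being described in identical words for both pairs. Because the earlier instance of this change gave a 1.5-fold lower number from compound 1 to compound 2 (0.17 log units; within the scatter), a step of similar size is expected here, namely a 1.4-fold lower number from compound 3 to compound 4 (0.15 log units; within the scatter). Compound 4 is accordingly estimated at 10 nM, with an expected range from 4 nM to 25 nM, resting on that single earlier occurrence.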

Compound 4, inhibition constant: 11 nM
Estimate against measurement, compound 4: 1.1-fold (0.04 log units) below; measured number inside the range.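

In this assay, propyl in place of phenyl on a saturated chain carbon bound to two saturated chain carbons gives, on the second core, a 1.3-fold lower number from compound 3 to compound 4 (0.10 log units; within the scatter). Set beside the earlier step, the change reads alike on both cores: the same change on two cores in this assay, a 1.5-fold lower number (0.17 log units; within the scatter) from compound 1 to compound 2 and a 1.3-fold lower number (0.10 log units; within the scatter) from compound 3 to compound 4, 1.2-fold (0.06 log units) apart, within the scatter of two such steps. This shows that, on these two cores, the exchange of phenyl for propyl leaves the number within the scatter, but with a single pair per core and both steps inside the scatter, it does not show that the change itself has a real effect on binding affinity, or that it would carry over to any further core.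

The compounds shown leave open how far this tolerance extends, since only phenyl and propyl appear on that saturated chain carbon. Going by these compounds, whether a longer chain such as hexyl, a cyclohexyl ring or an amine on the same carbon would keep the number in this range remains unknown.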